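A urea series where an amino group replaces chloro

This account rests on a few compounds, and the source may have more. Where it says the series, first, only, none or still open, it means among the compounds named here.

Compound 1 `Nc1nn(C(=O)Nc2ccc(Cc3ccccc3)cc2)c2ccccc12` is the starting point. In a functional assay on SN12C cells (Homo sapiens) for antiproliferative activity, read by sulforhodamine B assay, with a stated time of 48 h (on this read-out lower numbers stand for higher toxicity in this test and higher numbers for lower toxicity in this test), compound 1 gives 60600 nM. Compound 2 `Nc1nn(C(=O)Nc2ccc(Cc3ccccc3)cc2)c2ccc(Cl)cc12` carries a chloro on an aromatic carbon in place of a hydrogen; in this assay compound 2 gives > 100000 nM, which is a limit of the assay and not a measured number. The step of an at least 1.6-fold higher number from compound 1 to compound 2 (0.21 log units; that floor lies within the scatter) is accordingly known only as a floor. Compound 2 thus stands at the limit of > 100000 nM in this assay, at which 1 of the 2 values shown sits, with no number of its own. Compound 3 `Nc1ccc2c(c1)c(N)nn2C(=O)Nc1ccc(Cc2ccccc2)cc1` differs from compound 2 by amino in place of chloro on an aromatic carbon. Going by the values given here, no measured step swaps chloro for amino; the only step at hand, an at least 1.6-fold higher number from compound 1 to compound 2 (0.21 log units; that floor lies within the scatter), has a floor that lies within the scatter, so it gives little guidance on direction. Compound 3 is expected to remain weak, with an expected step of an at least 1.2-fold lower number from compound 2 to compound 3 (0.09 log units; that floor lies within the scatter) that is likely within the scatter. The estimate for compound 3 is 80000 nM, with a range from 30000 nM to 200000 nM.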

Compound 3, concentration lethal to 50% of the cells: 71100 nM
Compound 3: middle estimate off by 1.1-fold (0.05 log units), on the high side; the range from low to high includes it.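

With compound 3, this position on the shared core carries a group and gives a true number, which compound 2 could not provide. Amino in place of hydrogen gives a 1.2-fold higher number from compound 1 to compound 3 (0.07 log units; within the scatter), so amino at this position cannot be told from hydrogen in this assay. Amino in place of chloro gives an at least 1.4-fold lower number from compound 2 to compound 3 (0.14 log units; that floor lies within the scatter), and that step remains only a floor because compound 2 has a limit of the assay and no number of its own: the limit of > 100000 nM in this assay, at which 1 of the 3 values shown sits.

On these data alone, how far the true value of compound 2 lies from its limit remains unknown, so the full size of the chloro-to-amino step stays open. Also open, as far as these compounds go, is whether a different group at this position, such as a methoxy group or a carboxylic acid, would move the number beyond the scatter in either direction.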